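The source may report more compounds than this note shows. Statements on the series, on what has been measured and on what is new or still open speak of the compounds shown alone.

Measured in a functional assay on the whole organism with Mus musculus as the target, in the maximal electroshock model, with a stated time of 30 min; a lower number here means that less compound is needed, a higher number that more compound is needed for the effect:
compound 1 `N#Cc1cc[n+]([O-])cc1Oc1ccccc1`: 300 mg/kg
compound 2 `[O-][n+]1ccc(CO)c(Oc2ccccc2)c1`: 300 mg/kg

Compound 2 stands level with compound 1 at the digits shown; the step of no change at the digits printed from compound 1 to compound 2 (within the scatter) was no change within the scatter. Compound 3 `O=Cc1cc[n+]([O-])cc1Oc1ccccc1` differs from compound 2 by formyl in place of hydroxymethyl on an aromatic carbon. Within the data shown here, the only measured step that bears on this change is no change at the digits printed from compound 1 to compound 2 (within the scatter), which exchanged one group for another on an aromatic carbon of the shared core and left the minimum effective dose unchanged within the scatter. Nothing measured separates a formyl from a hydroxymethyl on that carbon, and the two measured compounds sit at one dose. The expectation for compound 3 in this assay is therefore no step beyond the scatter, no change at the digits printed from compound 2 to compound 3 (within the scatter). Compound 3 is estimated at 300 mg/kg, with a range from 150 mg/kg to 600 mg/kg.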

Compound 3, minimum effective dose: 300 mg/kg
Compound 3: the middle estimate sits on the measured number at the digits printed, within the range that was stated.
By their numbers in this assay, from the lowest: compounds 1, 2 and 3 (each within the scatter of the next).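

In this assay the step of no change at the digits printed from compound 2 to compound 3 (within the scatter) shows that formyl and hydroxymethyl cannot be told apart on this aromatic carbon opposite the ring nitrogen, although hydroxymethyl carries a hydrogen-bond donor and formyl carries none. Together with no change at the digits printed from compound 1 to compound 3 (within the scatter) this gives three groups on the same carbon, cyano, hydroxymethyl and formyl, with no exchange among them moving the minimum effective dose beyond the scatter. No measurement at hand offers an explanation for this flat reading.

Still open, going by these compounds, is whether this carbon responds to a group of another kind, such as an amine, a carboxylic acid or a longer alkyl chain. Also open, on these data alone, is whether replacing the group of 7 heavy atoms ortho to this carbon, which all three compounds share, would move the minimum effective dose.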